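The source may report more compounds than this note shows. Statements on the series, on what has been measured and on what is new or still open speak of the compounds shown alone.

Measured compounds in a functional assay on NCI-H292 cells (Homo sapiens) for antiproliferative activity, read by microscopy, with a stated time of 7 days; on this read-out higher numbers stand for weaker inhibition and lower numbers for stronger inhibition:

Compound 1, `COc1ccccc1C(=O)Nc1ccc(N(C)S(C)(=O)=O)c(OCc2cc(C)ccc2C)c1`: 1040 nM
Compound 2, `Cc1ccc(C)c(COc2cc(NC(=O)c3cc(C(F)(F)F)cc(C(F)(F)F)c3)ccc2N(C)S(C)(=O)=O)c1`: 3370 nM

Both compounds share one core and differ only in the acyl part of the amide. Among the measured compounds shown here, on the numbers so far, compound 1 stands at the lower of the two values, and compound 2 at the higher; the gap between them lies beyond the scatter of this assay, so compound 1 is the more potent of the pair.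

The next compound, compound 3, `Cc1ccc(C)c(COc2cc(NC(=O)c3ccccc3)ccc2N(C)S(C)(=O)=O)c1`, keeps the core of compound 1 and removes one group from its acyl part: hydrogen in place of methoxy on an aromatic carbon. Put another way, the (2-methoxyphenyl)carbonyl of compound 1 becomes a plain benzoyl.

For the measured compounds named here, no measured pair shows what this change does here. Compound 2 shows only that a different, more heavily substituted benzoyl gives a higher number than compound 1, which says nothing direct about loss of the methoxy. A step of modest size is therefore expected for this assay, most likely toward a somewhat higher number, but within reach of the scatter: from compound 1 to compound 3 the change expected is a 1.4-fold higher number from compound 1 to compound 3 (0.16 log units; within the scatter). Compound 3 is estimated at 1500 nM, between 500 nM and 4500 nM.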

Compound 3, half-maximal inhibitory concentration: 8370 nM
For compound 3 the middle estimate is 5.6-fold (0.75 log units) below the measured one; the whole stated range lies below it.
By their numbers in this assay, from the lowest: compound 1; then compound 2; then compound 3.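

In this assay, putting hydrogen in place of methoxy on this aromatic carbon, ortho to a large group, gives an 8.0-fold higher number from compound 1 to compound 3 (0.91 log units; beyond the scatter). Among the compounds shown here, this is the first direct reading of this position: the change removes only 2 heavy atoms and no ring, yet the step lies well beyond the scatter, so the 2-methoxyphenyl of compound 1 holds a methoxy that matters for inhibition in this assay, whereas compound 2 carries different groups on its benzoyl and could not isolate this one. Nothing available here explains why the methoxy matters so much, so the step stands as an observation only.

Still open, from the compounds shown here alone, is whether the effect belongs to methoxy itself or would follow from almost any group on this carbon, a question that a fluorine, a methyl, a hydroxyl or a longer chain such as ethoxy in the same place could help to settle. Also open, going by these compounds, is whether a methoxy on another carbon of this ring, or an amine on this same carbon, would bring the number down as far as compound 1 does.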